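Replacing methyl on the ring amine of compound 3

The source may report more compounds than this note shows. Statements on the series, on what has been measured and on what is new or still open speak of the compounds shown alone.

- compound 1 `CN(C[C@H]1Cc2c(cccc2N2CCN(C3COC3)CC2)CN1)[C@H]1CCCc2cccnc21`: 50.8%
- compound 2 `CN(C[C@H]1Cc2c(cccc2N2CCN(Cc3ccccn3)CC2)CN1)[C@H]1CCCc2cccnc21`: 40.4%
- compound 3 `CN1CCN(c2cccc3c2C[C@H](CN(C)[C@H]2CCCc4cccnc42)NC3)CC1`: 17%

In an ADME assay on microsomes from liver (Mus musculus) for metabolic stability, read by LC-MS, with a stated time of 10 min (on this read-out lower numbers stand for a less stable compound and higher numbers for a more stable compound), compound 3 stands lowest of the three, at 17%. Both steps that reach it lie beyond the scatter: a number 33.8 percentage points lower from compound 1 to compound 3 (beyond the scatter), and a number 23.4 percentage points lower from compound 2 to compound 3 (beyond the scatter). The next structure is compound 4 `CN(C[C@H]1Cc2c(cccc2N2CCN(c3ccccn3)CC2)CN1)[C@H]1CCCc2cccnc21`, which has pyridin-2-yl in place of methyl on an amine nitrogen in a ring.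

These two steps bear most directly on the change, since each ends at the methyl group on that nitrogen. Read in reverse, they show oxetan-3-yl and (pyridin-2-yl)methyl each with a higher number than methyl. For the measured compounds named here, compound 2 is the nearest match, but no measured compound has pyridin-2-yl directly on that nitrogen, so the size remains uncertain. An upward step of modest size is expected: a number 18 percentage points higher from compound 3 to compound 4 (beyond the scatter). For compound 4 the estimated value is 35%, with an expected range of 20% to 52%.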

Compound 4, percent of the compound remaining: 46.1%
Compound 4: the middle estimate sits 11.1 percentage points below what was measured; low and high end bracket the measured number.
By their numbers in this assay, from the lowest: compound 3; then compounds 2, 4 and 1 (each within the scatter of the next, the first and the last beyond it).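

In this assay, pyridin-2-yl bound directly to the amine nitrogen in a ring also clears methyl, a number 29.1 percentage points higher from compound 3 to compound 4 (beyond the scatter), so a higher number at this position does not depend on the (pyridin-2-yl)methyl chain. Dropping that chain gives no readable change, a number 5.7 percentage points higher from compound 2 to compound 4 (within the scatter), and pyridin-2-yl cannot be separated from oxetan-3-yl either, a number 4.7 percentage points lower from compound 1 to compound 4 (within the scatter); among these compounds, compound 3 alone stands apart, while oxetan-3-yl and (pyridin-2-yl)methyl remain beyond the scatter of each other. Nothing measured here accounts for these differences.

Phenyl at this nitrogen would test whether the ring nitrogen of pyridin-2-yl matters to the read-out. From the compounds shown here alone, whether small non-aromatic groups such as ethyl or acetyl match pyridin-2-yl or stay nearer methyl remains open.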